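The compounds below may be only part of what the source reports. "The series", "measured", "known", "first", "only" and "open" are said of these compounds alone.

Compound 3 `CN1C=CC(C2OC(C(F)(F)F)=CN2c2ccc(S(N)(=O)=O)cc2)C=C1` and compound 1 `CN1C=CN(C2OC(C(F)(F)F)=CN2c2ccc(S(N)(=O)=O)cc2)C=C1` share a core; in a physicochemical assay for acid dissociation, compound 3 gives 7.33 and compound 1 gives 7.18. The change between them, (a group of 7 heavy atoms (5 carbon, 2 nitrogen; one six-membered non-aromatic ring with 2 hetero atoms) in place of a group of 7 heavy atoms (6 carbon, 1 nitrogen; one six-membered non-aromatic ring with 1 hetero atom), on a saturated ring carbon), made a step of a number 0.15 log units lower from compound 3 to compound 1 (within the scatter). Compound 2 `CN1C=CC(C2SC(C(F)(F)F)=CN2c2ccc(S(N)(=O)=O)cc2)C=C1` rests on another core; the difference between the two cores is not broken down here. In this assay compound 2 gives 7.62, with compound 3 within the scatter of it and compound 1 beyond it. Compound 4 `CN1C=CN(C2SC(C(F)(F)F)=CN2c2ccc(S(N)(=O)=O)cc2)C=C1` is not yet measured. It differs from compound 2 by a group of 7 heavy atoms (5 carbon, 2 nitrogen; one six-membered non-aromatic ring with 2 hetero atoms) in place of a group of 7 heavy atoms (6 carbon, 1 nitrogen; one six-membered non-aromatic ring with 1 hetero atom), on a saturated ring carbon, the same kind of change, here on a saturated ring carbon of a five-membered non-aromatic ring with 1 nitrogen and 1 sulfur, next to the ring sulfur, rather than one with 1 nitrogen and 1 oxygen, next to the ring oxygen. Because the same kind of change gave a number 0.15 log units lower from compound 3 to compound 1 (within the scatter), the expected step is a number 0.15 log units lower from compound 2 to compound 4 (within the scatter). The estimate for compound 4 in this assay is 7.47, between 7.2 and 7.75.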

Compound 4, acid dissociation constant: 7.5
Compound 4: middle estimate off by 0.03 log units, on the low side; measured number inside the range.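

In this assay, the change gave a number 0.12 log units lower from compound 2 to compound 4 (within the scatter), and on the core of compound 3 the same kind of change gave a number 0.15 log units lower from compound 3 to compound 1 (within the scatter). Neither step lies beyond the scatter, so the two pairs show that the change carried from one core to the other without a step beyond the scatter, but they do not show that the change has a real effect of any particular size, and two pairs set no rule for other cores. Nothing in the data bears on what lies behind these numbers.

On these data alone, it remains open whether the same would hold with an amine at the saturated ring carbon. The same question stands for a nitrile or a carboxylic acid in place of the trifluoromethyl group.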